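Removing a Fluoro Group on a Second Core

The compounds below may be only part of what the source reports. "The series", "measured", "known", "first", "only" and "open" are said of these compounds alone.

Compound 1, `C=CC(=O)N1CCC(Oc2nc(Nc3ccc(N4CCN(C)CC4)c(F)c3)nc3[nH]ccc23)CC1`, gives 3020 nM in a toxicity assay on cells (Epithelial cell, Homo sapiens) for cytotoxicity, read by MTT assay, with a stated time of 72 h; on this read-out lower numbers stand for stronger inhibition and higher numbers for weaker inhibition.
Compound 2, `C=CC(=O)N1CCC(Oc2nc(Nc3ccc(N4CCN(C)CC4)cc3)nc3[nH]ccc23)CC1`, gives 7940 nM in this assay.
Compound 3, `C=CC(=O)N1CCC(Oc2nc(Nc3ccc(N4CCN(C)CC4)c(F)c3)nc3ccsc23)CC1`, gives 4050 nM in this assay.

Compound 1 and compound 2 share one core and differ in one place: hydrogen in place of fluoro on an aromatic carbon. That change gives a 2.6-fold higher number from compound 1 to compound 2 (0.42 log units; beyond the scatter), a step beyond the usual scatter of the measurement, so removing the fluoro group weakens the cytotoxic effect on this pair.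

Compound 3 carries a different core, and the difference between its core and that of compound 1 is not broken down here. Its value in this assay sits within the usual scatter of both compound 1 and compound 2, so nothing can be said about its order relative to either of them.

Compound 4, `C=CC(=O)N1CCC(Oc2nc(Nc3ccc(N4CCN(C)CC4)cc3)nc3ccsc23)CC1`, has not yet been measured in this assay. It differs from compound 3 in one place: hydrogen in place of fluoro on an aromatic carbon. This is the same change that turns compound 1 into compound 2, and it is made here on the core of compound 3. Because the measured pair shows a 2.6-fold higher number from compound 1 to compound 2 (0.42 log units; beyond the scatter), a step of similar size is expected on the second core, though the change has been seen only once and the cores differ.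

On that basis compound 4 is expected to give 9500 nM in this assay, with a plausible range from 4500 nM to 22000 nM.
The estimated step from compound 3 to compound 4 is therefore a 2.3-fold higher number from compound 3 to compound 4 (0.37 log units; beyond the scatter).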

Compound 4, half-maximal inhibitory concentration: 9050 nM
Estimate against measurement, compound 4: 1.0-fold (0.02 log units) above; the measured number falls inside the stated range.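

Removing the fluoro group, which sits ortho to the 4-methylpiperazin-1-yl group, gives a 2.2-fold higher number from compound 3 to compound 4 (0.35 log units; beyond the scatter) in this assay, so the second core moves in the same direction as the first. The step carries over from one core to the other with little change in size, and the two steps cannot be told apart: the same change on two cores in this assay, a 2.6-fold higher number (0.42 log units; beyond the scatter) from compound 1 to compound 2 and a 2.2-fold higher number (0.35 log units; beyond the scatter) from compound 3 to compound 4, 1.2-fold (0.07 log units) apart, within the scatter of two such steps This shows that, for these two pairs, the effect of this change on the read-out holds when the core is exchanged, but it does not show that the step would hold on any further core, and it gives no reason why hydrogen in place of fluoro raises the number on either pair.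

On these data alone, the four compounds carry only fluoro or hydrogen at this place, so it remains open how a chloro group, a methyl group or a methoxy group there would compare on either core. All four also keep the 4-methylpiperazin-1-yl group, which leaves open whether the same step would appear with a morpholine or a short dimethylamino chain in its place.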